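A Pyrazole for a Pyridine on the Hydroxy Side Chain

The source may hold more compounds than are shown below. What is called first, only, known or untested is meant among the compounds shown, and "the series" means these compounds.

Compound 1 `O=C(NCc1cc(Cl)ccc1-n1cnnn1)[C@@H]1C[C@@H]2C[C@@H]2N1C(=O)[C@H](O)Cc1ccccn1` was examined in an ADME assay on liver for metabolic stability, with Liver microsome (Homo sapiens) as the target, read by LC-MS, using microsomes (on this read-out lower numbers stand for slow clearance and higher numbers for fast clearance), where compound 1 gives 17 mL.min-1.g-1. Of the two numbers available, that of compound 1 is the lowest; the nearest is compound 3 `CC(C)(C)OC[C@@H](O)C(=O)N1C[C@@H]2C[C@@H]2[C@H]1C(=O)NCc1cc(Cl)ccc1-n1cnnn1`, which in this assay gives 37 mL.min-1.g-1, a gap beyond the usual scatter. For compound 2 `CC(C)(C)[C@@H](O)C(=O)N1C[S+]([O-])C[C@H]1C(=O)NCc1cc(Cl)ccc1-n1cnnn1` the assay reports only a limit, (the limit of < 12 mL.min-1.g-1 in this assay, at which 1 of the 3 values shown sits), so in this assay compound 2 reads < 12 mL.min-1.g-1. The not yet measured compound 4 `O=C(NCc1cc(Cl)ccc1-n1cnnn1)[C@@H]1C[C@@H]2C[C@@H]2N1C(=O)[C@H](O)Cn1cccn1` differs from compound 1 in one place: 1H-pyrazol-1-yl in place of pyridin-2-yl on a saturated chain carbon, two bonds along the chain from a carbonyl carbon and an oxygen on a saturated carbon. Among the measured compounds shown here, no step between two measured compounds covers such a change, so the size of its effect is open; a modest shift is expected, if any, toward slower clearance or else within the scatter. Compound 4 is therefore expected to give about 14 mL.min-1.g-1 in this assay, between 8 mL.min-1.g-1 and 28 mL.min-1.g-1. The step this estimate implies is a 1.2-fold lower number from compound 1 to compound 4 (0.08 log units; within the scatter), which is expected to be small.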

Compound 4, intrinsic clearance in microsomes: < 12 mL.min-1.g-1
Compound 4: no number, only a limit; the forecaster's own chance of this, stated with the estimate: 30%; middle value at least 1.1-fold (0.06 log units) from the limit.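

In this assay compound 4 gives no number, only a limit, and it is the same limit at which compound 2 sits: the limit of < 12 mL.min-1.g-1 in this assay, at which 2 of the 4 values shown sit. Among the compounds shown here, replacing pyridin-2-yl with 1H-pyrazol-1-yl on this saturated chain carbon is the first single change seen at this position, and it gives an at least 1.4-fold lower number from compound 1 to compound 4 (0.15 log units; that floor lies within the scatter). The change therefore does not raise the number, but that floor lies within the scatter, so the limit does not establish a real drop in clearance.

The compounds shown leave open the true size of this step and whether it would hold on a core other than that of compound 1. They also leave open how a phenyl ring or a primary amine would read in the same place on the chain.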